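The source may report more compounds than this note shows. Statements on the series, on what has been measured and on what is new or still open speak of the compounds shown alone.

Measured so far in a functional assay on CCRF-CEM cells for antagonist activity at C-X-C chemokine receptor type 4 (Homo sapiens), read by calcium flux, with stated times of 25 min and 90 s; a lower number here means a stronger inhibitor, a higher number a weaker inhibitor:
- compound 1 `CN(C[C@H]1Cc2c(cccc2N2CCN(C3COC3)CC2)CN1)[C@H]1CCCc2cccnc21`: 381 nM
- compound 2 `CN(C[C@H]1Cc2c(cccc2N2CCNC(C)(C)C2)CN1)[C@H]1CCCc2cccnc21`: 33.9 nM
- compound 3 `C[C@@H]1CN(c2cccc3c2C[C@H](CN(C)[C@H]2CCCc4cccnc42)NC3)C[C@H](C)N1C`: 14.1 nM

Compound 1 has the highest number of the three in this assay, so it is the weakest inhibitor shown. Changing the group on the piperazine gave large gains: an 11-fold lower number from compound 1 to compound 2 (1.05 log units; beyond the scatter) and a 27-fold lower number from compound 1 to compound 3 (1.43 log units; beyond the scatter), while the further step a 2.4-fold lower number from compound 2 to compound 3 (0.38 log units; beyond the scatter) was modest. Compound 4 `CN(C[C@H]1Cc2c(cccc2N2CCN(c3ncccn3)CC2)CN1)[C@H]1CCCc2cccnc21` differs from compound 1 by pyrimidin-2-yl in place of oxetan-3-yl on an amine nitrogen in a ring. Among the measured compounds shown here, no measured step tests this particular replacement, so the two large steps only show that the oxetan-3-yl group can be replaced with benefit. For compound 4 a smaller change is expected: a 1.5-fold lower number from compound 1 to compound 4 (0.18 log units; within the scatter). The estimate for compound 4 is 250 nM, with a range from 70 nM to 1000 nM.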

Compound 4, half-maximal inhibitory concentration: 30.7 nM
Compound 4: the middle estimate sits 8.1-fold (0.91 log units) above what was measured; measured number below the stated range.
By their numbers in this assay, from the lowest: compound 3; then compounds 4 and 2 (each within the scatter of the next); then compound 1.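

On the amine nitrogen of the piperazine, replacing oxetan-3-yl with the six-membered aromatic pyrimidin-2-yl gives a large gain on its own: a 12-fold lower number from compound 1 to compound 4 (1.09 log units; beyond the scatter). The earlier steps shown here away from compound 1 also brought methyl groups onto the piperazine, whereas this step changes only the group on that nitrogen. A larger aromatic ring is therefore compatible with good activity at this place. Nothing measured here gives a reason for the gain. As far as these compounds go, it remains open whether the gain depends on the two ring nitrogens of pyrimidin-2-yl; a phenyl or pyridin-2-yl group on this nitrogen would test that.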